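The source may report more compounds than this note shows. Statements on the series, on what has been measured and on what is new or still open speak of the compounds shown alone.

Within the data shown here, compound 1 `COc1cc(-c2nn(-c3cccc(NC(=O)c4cccc(C(F)(F)F)c4)c3)cc2-c2ccncc2)ccc1Cl` is one of two compounds measured in a functional assay on SF-539 cells (Homo sapiens) for inhibition, read by sulforhodamine B assay, with a stated time of 48 h; a higher number here means a weaker inhibitor of growth, a lower number a stronger inhibitor of growth. In this assay compound 1 gives 2300 nM, the higher of the two numbers. Compound 2 `O=C(Nc1cccc(-n2cc(-c3ccncc3)c(-c3ccc(Cl)c(O)c3)n2)c1)Nc1cc(C(F)(F)F)cc(C(F)(F)F)c1` gives 1490 nM in this assay, and its gap to compound 1 lies within the scatter. Compound 3 `COc1cc(-c2nn(-c3cccc(NC(=O)Nc4ccc(Cl)c(Cl)c4)c3)cc2-c2ccncc2)ccc1Cl` has not yet been measured. It differs from compound 1 in one place: (3,4-dichlorophenyl)amino in place of 3-(trifluoromethyl)phenyl on a carbonyl carbon. Because compound 2 gives 1490 nM, a nearby result is expected for compound 3. The step of a 1.8-fold lower number from compound 1 to compound 3 (0.25 log units; within the scatter) is expected to stay within the scatter. Compound 3 is estimated at 1300 nM, with a range from 450 nM to 3800 nM.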

Compound 3, concentration for total growth inhibition: 3080 nM
For compound 3 the middle estimate is 2.4-fold (0.37 log units) below the measured one; the measured number falls inside the stated range.
By their numbers in this assay, from the lowest: compounds 2, 1 and 3 (each within the scatter of the next, the first and the last beyond it).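

In this assay, the step gives a 1.3-fold higher number from compound 1 to compound 3 (0.13 log units; within the scatter). This carbonyl carbon therefore carries either 3-(trifluoromethyl)phenyl or (3,4-dichlorophenyl)amino, with its added hydrogen-bond donor, without a readable difference in growth inhibition. Nothing measured here offers an explanation for this result.

The amino nitrogen and the ring substituents change together, so their separate contributions remain unresolved. Also open, on these data alone, is how a cyclohexyl group or a morpholine, neither of which has an aromatic ring, would read on this carbonyl carbon.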